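The source may hold more compounds than are shown below. What is called first, only, known or untested is meant among the compounds shown, and "the series" means these compounds.

Measured so far in a functional assay on MCF7 cells (Homo sapiens) for inhibition, read by MTT assay, with a stated time of 48 h; on this read-out higher numbers stand for weaker inhibition and lower numbers for stronger inhibition:

Compound 1 `Brc1ccc(C(c2c[nH]c3ccc(Br)cc23)c2c[nH]c3ccc(Br)cc23)cc1` gives 3200 nM.
Compound 2 `O=[N+]([O-])c1ccc(C(c2c[nH]c3ccc(Br)cc23)c2c[nH]c3ccc(Br)cc23)cc1` gives 3100 nM.
Compound 3 `N#Cc1ccc2[nH]cc(C(c3ccc(Br)cc3)c3c[nH]c4ccc(C#N)cc34)c2c1` gives 27100 nM.

Compound 2 differs from compound 1 by one change, (nitro in place of bromo on an aromatic carbon), and this change made a 1.0-fold lower number from compound 1 to compound 2 (0.01 log units; within the scatter). Compound 4 `N#Cc1ccc2[nH]cc(C(c3ccc([N+](=O)[O-])cc3)c3c[nH]c4ccc(C#N)cc34)c2c1` is not yet measured; it differs from compound 3 by nitro in place of bromo on an aromatic carbon, which is the same change as the one already seen, since the place is described in identical words in both cases. The difference between the core of compound 1 and the core of compound 3 is not broken down here. Because the earlier step was a 1.0-fold lower number from compound 1 to compound 2 (0.01 log units; within the scatter), the step from compound 3 to compound 4 is expected to be a 1.0-fold lower number from compound 3 to compound 4 (0.00 log units; within the scatter), and the expected value for compound 4 is estimated as 27000 nM, most likely falling between 12000 nM and 60000 nM.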

Compound 4, half-maximal inhibitory concentration: 23600 nM
Beside the measured number, compound 4's estimate is 1.1-fold (0.06 log units) above it; the measured number falls inside the stated range.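

In this assay, replacing 4-bromophenyl with 4-nitrophenyl gives a 1.1-fold lower number from compound 3 to compound 4 (0.06 log units; within the scatter), so on this core the swap has no effect that can be told from assay noise. The swap reads the same on both cores, so in this small set it carries over: the same change on two cores in this assay, a 1.0-fold lower number (0.01 log units; within the scatter) from compound 1 to compound 2 and a 1.1-fold lower number (0.06 log units; within the scatter) from compound 3 to compound 4, 1.1-fold (0.05 log units) apart, within the scatter of two such steps. Among the compounds shown here, this shows only that a swap with no visible effect stayed that way on two cores; it does not show that a swap with a real effect would carry over equally, that a third core would behave alike, or why the two groups read the same.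

The compounds shown leave open whether a different group in this place, such as an amine or a carboxylic acid, would move the number at all. If one did, it would remain to be seen whether it moved the number equally on both cores.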